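Stereochemical inversion of a peroxide acid

The compounds below may be only part of what the source reports. "The series", "measured", "known", "first", "only" and "open" are said of these compounds alone.

Compound 1 `C=C1CCCC(C)(C)C1CC[C@]1(C)CC[C@@H]([C@@H](C)C(=O)O)OO1` is recorded in a functional assay on SK-MEL-28 cells (Homo sapiens) for inhibition (on this read-out lower numbers stand for stronger inhibition of growth and higher numbers for weaker inhibition of growth), only as a limit, > 10000 nM; this is the limit of > 10000 nM in this assay, at which 1 of the 3 values shown sits. Compound 2 `C=C1CCCC(C)(C)C1CC[C@]1(C)CC[C@H]([C@@H](C)C(=O)OC)OO1` gives 20600 nM in this assay. Compound 3 `C=C1CCCC(C)(C)C1(O)CC/C(C)=C/CC[C@]1(C)CC[C@@H]([C@@H](C)C(=O)OC)OO1` likewise reaches only a limit in this assay, > 17500 nM; this is the limit of > 17500 nM in this assay, at which 1 of the 3 values shown sits. All three values thus sit in the region of weak growth inhibition. Compound 4 `C=C1CCCC(C)(C)C1CC[C@@]1(C)CC[C@H]([C@@H](C)C(=O)O)OO1` keeps every atom and bond of compound 1 and differs only in configuration: the two compounds have the same atoms and bonds; at least one stereo element is drawn with a configuration in one of them and without one in the other: 2 of 4 stereo elements differ; a stereocentre at a saturated ring carbon is drawn R in compound 1 and S in compound 4; a stereocentre at a saturated ring carbon is drawn S in compound 1 and R in compound 4. Within the data shown here, no measured pair differs in a single place, so no step size is known from the data. Given this, the step that the limit leaves unreadable from compound 1 to compound 4 is expected to stay within the scatter. Compound 4 is estimated at 20000 nM, with a range of 8000 nM to 60000 nM.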

Compound 4, concentration for 50% growth inhibition: > 12500 nM
Compound 4 ended at the assay's limit; the forecaster's own chance of this, stated with the estimate: 60%; the middle value is on the limit's open side.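

Among these compounds, compound 1 and compound 4 are both recorded only as limits, so no step between them can be read. The compounds shown leave open whether the two differing stereocentres affect growth inhibition in this assay at all.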